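A few compounds are considered here, and "the series" means these few. Any claim that something is new, unique, unknown or untested is made for them only; others in the source may bear on it.

Compound 1 `CC(=O)c1ccc(NC(=O)C(CC(C)C)N(C(=O)c2ccccc2)S(=O)(=O)c2ccc([N+](=O)[O-])cc2)cc1` is the reference of this small set: in a functional assay for inhibition, read by spectrophotometry, with a stated time of 20 min, tested at 4 mg/mL (a higher number here means a stronger effect of the compound at the concentration tested, a lower number a weaker effect), compound 1 gives 71%. Compound 2 `CCC(C)C(C(=O)Nc1ccc(C(C)=O)cc1)N(C(=O)c1ccccc1)S(=O)(=O)c1ccc([N+](=O)[O-])cc1` differs from it only by sec-butyl in place of isobutyl on a saturated chain carbon bound to an amide-type nitrogen and a carbonyl carbon and in this assay compound 2 gives 48.4%, so the change produced a number 22.6 percentage points lower from compound 1 to compound 2 (beyond the scatter). Compound 3 `CC(=O)c1ccc(NC(=O)C(CC(C)C)N(C(=O)c2ccccc2)S(=O)(=O)c2ccccc2)cc1` keeps the isobutyl of compound 1 and changes the core: the difference between the two cores is hydrogen in place of nitro on an aromatic carbon. In this assay compound 3 gives 46.9%, a step of a number 24.1 percentage points lower from compound 1 to compound 3 (beyond the scatter). The values of compound 2 and compound 3 lie within the scatter of each other, so nothing separates them.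

Compound 4 `CCC(C)C(C(=O)Nc1ccc(C(C)=O)cc1)N(C(=O)c1ccccc1)S(=O)(=O)c1ccccc1` is not yet measured. It stands to compound 3 as compound 2 stands to compound 1, by sec-butyl in place of isobutyl on a saturated chain carbon bound to an amide-type nitrogen and a carbonyl carbon, on the same place and therefore the same change, now on the core of compound 3. Within the data shown here, a step comparable to a number 22.6 percentage points lower from compound 1 to compound 2 (beyond the scatter) is expected, so the estimated step is a number 18.9 percentage points lower from compound 3 to compound 4 (beyond the scatter), resting on the single earlier pair alone. Compound 4 is expected to give about 28% in this assay, within a range of 10% to 46%.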

Compound 4, a percentage reported as inhibition, at one concentration (the size of the read-out at that concentration, not a potency): 15.5%
The estimate for compound 4 lay 12.5 percentage points above the measured number, within the range that was stated.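

Sec-butyl in place of isobutyl on a saturated chain carbon bound to an amide-type nitrogen and a carbonyl carbon gives, in this assay, a number 31.4 percentage points lower from compound 3 to compound 4 (beyond the scatter), so the step seen on the core of compound 1 carries over to the core of compound 3 at a comparable size: the same change on two cores in this assay, a number 22.6 percentage points lower (beyond the scatter) from compound 1 to compound 2 and a number 31.4 percentage points lower (beyond the scatter) from compound 3 to compound 4, 8.8 percentage points apart, within the scatter of two such steps

Hydrogen in place of nitro on an aromatic carbon gives a number 32.9 percentage points lower from compound 2 to compound 4 (beyond the scatter), so this change also carries over, here from the isobutyl pair to the sec-butyl pair: the same change on two cores in this assay, a number 24.1 percentage points lower (beyond the scatter) from compound 1 to compound 3 and a number 32.9 percentage points lower (beyond the scatter) from compound 2 to compound 4, 8.8 percentage points apart, within the scatter of two such steps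

Both comparisons rest on the same four compounds, with one pair for each change on each side, so they show that the two changes add up within the scatter here, but not that this would hold on any further core, nor why either change lowers the number.

On these data alone, how an amine or a nitrile in place of nitro on an aromatic carbon would read remains open. So does the effect of a longer chain or a benzyl group in place of isobutyl on the saturated chain carbon.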